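A Larger Amide Substituent on Compound 3

The source may report more compounds than this note shows. Statements on the series, on what has been measured and on what is new or still open speak of the compounds shown alone.

compound 1 `Cc1ccc2[nH]c(C(=O)N[C@H]3CN(S(=O)(=O)c4ccccc4)C[C@@H]3C(=O)NC[C@H]3CCCN3C)cc2c1` – 0.08 10^-6 cm/s
compound 2 `O=C(N[C@H]1CN(S(=O)(=O)c2ccccc2)C[C@@H]1C(=O)N[C@H]1CCCNC1)c1ccc(-c2cc(C(F)(F)F)ccc2Cl)o1` – 0.07 10^-6 cm/s
compound 3 `O=C(N[C@H]1CN(S(=O)(=O)c2ccccc2)C[C@@H]1C(=O)NC[C@@H]1CCCN1)c1cc(-c2ccccc2Cl)on1` – 0.44 10^-6 cm/s

In an ADME assay on Caco-2 cells (Homo sapiens) for permeability, in the apical to basolateral direction, at pH 7.4 (on this read-out higher numbers stand for higher permeability and lower numbers for lower permeability), compound 3 gives the highest of the three numbers (0.44 10^-6 cm/s). Compound 1 (0.08 10^-6 cm/s) and compound 2 (0.07 10^-6 cm/s) both lie lower than compound 3, in each case beyond the usual scatter of the measurement, and they sit within that scatter of each other. No two of these compounds differ in only one place, so the data offer no measured step that could be carried over to a new change.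

Compound 4 `O=CN1CCC[C@H](NC(=O)[C@H]2CN(S(=O)(=O)c3ccccc3)C[C@@H]2NC(=O)c2cc(-c3ccccc3Cl)on2)C1` differs from compound 3 in one place, on an amide-type nitrogen (a group of 8 heavy atoms (6 carbon, 1 nitrogen, 1 oxygen; one six-membered non-aromatic ring with 1 hetero atom) in place of a group of 6 heavy atoms (5 carbon, 1 nitrogen; one five-membered non-aromatic ring with 1 hetero atom), on an amide-type nitrogen). A six-membered non-aromatic ring thus stands where compound 3 has a five-membered one. For the measured compounds named here, no measured compound carries the entering group, so the expectation rests on the counted change and on compound 3 as the only anchor (0.44 10^-6 cm/s).

In this assay the expected change is upward and beyond the scatter, an estimated 2.7-fold higher number from compound 3 to compound 4 (0.44 log units; beyond the scatter) with wide uncertainty. The expected value for compound 4 is 1.2 10^-6 cm/s (estimated range 0.3 10^-6 cm/s to 4 10^-6 cm/s).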

Compound 4, apparent permeability: 0.96 10^-6 cm/s
Compound 4: middle estimate off by 1.3-fold (0.10 log units), on the high side; the range from low to high includes it.
By their numbers in this assay, from the lowest: compounds 2 and 1 (each within the scatter of the next); then compound 3; then compound 4.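

For the compounds shown here, at the amide-type nitrogen, in this assay, replacing the (pyrrolidin-2-yl)methyl group with the larger six-membered ring group gives a 2.2-fold higher number from compound 3 to compound 4 (0.34 log units; beyond the scatter), which is the first measured step in this set and shows that a change at this position alone can move the number beyond the scatter. The step bundles several counted differences: the entering group has a six-membered rather than a five-membered non-aromatic ring, 8 heavy atoms rather than 6, a double bond outside aromatic rings, and 0 hydrogen-bond donors rather than 1, and this single step cannot separate their contributions. No available evidence bears on why the number rises.

From the compounds shown here alone, it remains open how a six-membered ring group holding a plain secondary amine or an acetyl amide would compare, so the ring size cannot yet be told apart from the other features of the entering group. Going by these compounds alone, it is also open whether the same change would give a similar step on compounds with other groups elsewhere in the molecule, since this is the only step at this position.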